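This account rests on a few compounds, and the source may have more. Where it says the series, first, only, none or still open, it means among the compounds named here.

Working notes on the series.

The series rests on a shared core, seen in compound 1 `Cc1nn(Cc2ccccc2)c(C)c1NC(=O)c1ccc(COc2ccccc2)cc1`, which in a functional assay on MIA PaCa-2 cells (Homo sapiens) for antiproliferative activity, read by MTT assay, with a stated time of 72 h (on this read-out higher numbers stand for an effect only at larger amounts of compound and lower numbers for an effect already at smaller amounts), gives 10000 nM. Compound 2 `Cc1nn(Cc2ccccc2C(N)=O)c(C)c1NC(=O)c1ccc(COc2ccccc2)cc1` carries a carbamoyl group on the benzyl ring and in this assay gives 42000 nM. Within the data shown here, the only step so far, a 4.2-fold higher number from compound 1 to compound 2 (0.62 log units; beyond the scatter), records that this addition worsened the read-out. Among the measured compounds shown here, on the numbers in hand compound 2 therefore stands at the higher end, with compound 1 as its only neighbour and the step between them beyond the scatter.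

Compound 3 `CCNC(=O)c1cccc(Cn2nc(C)c(NC(=O)c3ccc(COc4ccccc4)cc3)c2C)c1` is not yet measured. Relative to compound 2 the change is 3-(ethylcarbamoyl)phenyl in place of 2-carbamoylphenyl on a saturated chain carbon bound to an aromatic nitrogen. For the measured compounds named here, no measured step covers this pairing directly: the only step, a 4.2-fold higher number from compound 1 to compound 2 (0.62 log units; beyond the scatter), bears on whether a carbamoyl group is present at all, not on where it sits or on the ethyl on its nitrogen. Since the amide is kept in compound 3, the expectation is a number in the region of compound 2, with a modest movement toward compound 1 possible but not assured. The estimated step is a 1.7-fold lower number from compound 2 to compound 3 (0.23 log units; within the scatter). For compound 3 in this assay the estimate is 25000 nM, within 8000 nM to 80000 nM.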

Compound 3, half-maximal effective concentration: 11000 nM
Beside the measured number, compound 3's estimate is 2.3-fold (0.36 log units) above it, and the stated range covers the measured number.
By their numbers in this assay, from the lowest: compounds 1 and 3 (each within the scatter of the next); then compound 2.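

The carbamoyl penalty seen earlier does not extend to every amide on the benzyl ring: in this assay, 3-(ethylcarbamoyl)phenyl in place of 2-carbamoylphenyl on a saturated chain carbon bound to an aromatic nitrogen gives a 3.8-fold lower number from compound 2 to compound 3 (0.58 log units; beyond the scatter). Set against the unsubstituted benzyl group, ethylcarbamoyl gives a 1.1-fold higher number from compound 1 to compound 3 (0.04 log units; within the scatter), so this position tolerates that amide without a measurable cost, and compound 1 and compound 3 cannot be told apart on this read-out. Among these compounds, no measurement in hand accounts for the difference between the two amides, and the series so far offers no independent data on its origin.

The step from compound 2 to compound 3 changes both where the amide sits and whether its nitrogen carries an ethyl group, so the compounds shown do not separate these two contributions. Also open, going by these compounds, is whether the tolerance extends beyond this one amide, for instance to a longer chain than ethyl on the amide nitrogen, or to a carboxylic acid or an amine in its place, and whether any such group would bring the number below that of compound 1.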